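Estimating Compound 4 from Three Compounds at the Limit

A few compounds are considered here, and "the series" means these few. Any claim that something is new, unique, unknown or untested is made for them only; others in the source may bear on it.

compound 1 `O=C(Nc1ccc(Sc2nc3ccccc3s2)cc1)c1ccccc1` — in an assay on isolated protein for inhibition of thiosulfate sulfurtransferase (Homo sapiens), with a stated time of 60 min, in the absence of a further agent (a higher number here means a weaker inhibitor, a lower number a stronger inhibitor), compound 1 gives > 100000 nM, a limit of the assay.
compound 2 `O=C(Nc1ccc(Sc2nc3ccccc3s2)c(Cl)c1)c1cccc(Br)c1` — in this assay compound 2 gives > 100000 nM, a limit of the assay.
compound 3 `COc1c(Br)cccc1C(=O)Nc1ccc(Sc2nc3ccccc3s2)c(Cl)c1` — in this assay compound 3 gives > 100000 nM, a limit of the assay.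

Compound 3 stands only at a limit in this assay, and since the two other values are limits as well, its place relative to them cannot be read. Compound 4 `O=C(Nc1ccc(Sc2nc3ccccc3s2)c(Cl)c1)c1ccccc1` differs from compound 3 by a group of 6 heavy atoms (6 carbon; one six-membered aromatic ring of carbon only) in place of a group of 9 heavy atoms (7 carbon, 1 oxygen, 1 bromine; one six-membered aromatic ring of carbon only), on a carbonyl carbon. Among the compounds with values here, the single measured step, a step that the two limits leave unreadable from compound 2 to compound 3, lies between two limits, and the limit of > 100000 nM in this assay, at which 3 of the 3 values shown sit, shows that all three values sit at that same limit. Within the data shown here, no measured step therefore gives a readable size or direction for this change. Compound 4 is thus expected to give 200000 nM, within 100000 nM to 1000000 nM, most probably again as a limit. The step that the limit leaves unreadable from compound 3 to compound 4 is expected to be none beyond the scatter.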

Compound 4, half-maximal inhibitory concentration: > 100000 nM
Compound 4 was reported as a limit (the forecaster's own chance of this, stated with the estimate: 90%); the middle value is on the limit's open side.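

The steps to compound 4 from compound 1, compound 2 and compound 3 cannot be read, since each pair sits at one limit: the limit of > 100000 nM in this assay, at which 4 of the 4 values shown sit.

The compounds shown leave open how strongly any of them inhibits and whether any of these changes alters that inhibition.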